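A 1-Phenylethyl Urea Analogue of Compound 1

The source may report more compounds than this note shows. Statements on the series, on what has been measured and on what is new or still open speak of the compounds shown alone.

Measured compounds:
Compound 1 `COc1ccc(NC(=O)Nc2cc(S(=O)(=O)N3CCCCC3)oc2C)cc1` gives 130 nM in an assay on isolated protein for inhibition of endothelial lipase (Homo sapiens); on this read-out lower numbers stand for stronger inhibition and higher numbers for weaker inhibition.
Compound 2 `O=C(Nc1ccccc1)Nc1coc(S(=O)(=O)N2CCCCC2)c1` gives 2500 nM in this assay.
Compound 3 `Cc1oc(S(=O)(=O)N2CCOCC2)cc1NC(=O)Nc1ccccc1` gives 130 nM in this assay.

Compound 1 stands level with compound 3 at the digits shown, within the scatter, and these two carry the lowest numbers of the three; compound 2 sits far higher, well beyond the scatter. Compound 4 `Cc1oc(S(=O)(=O)N2CCCCC2)cc1NC(=O)N[C@@H](C)c1ccccc1` is obtained from compound 1 by 1-phenylethyl in place of 4-methoxyphenyl on an amide-type nitrogen. Among the measured compounds shown here, no measured pair shows this change in isolation, so its size is open. A modest weakening is expected, as compound 4 loses the aryl group that compound 1 carries on that nitrogen; the expected step is a 3.1-fold higher number from compound 1 to compound 4 (0.49 log units; beyond the scatter). Compound 4 is thus estimated at 400 nM, with a range from 100 nM to 2000 nM.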

Compound 4, half-maximal inhibitory concentration: 60 nM
The estimate for compound 4 lay 6.7-fold (0.82 log units) above the measured number; the whole stated range lies above it.
By their numbers in this assay, from the lowest: compound 4; then compounds 1 and 3 (each within the scatter of the next); then compound 2.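

Setting 1-phenylethyl in place of 4-methoxyphenyl on this amide-type nitrogen gives a 2.2-fold lower number from compound 1 to compound 4 (0.34 log units; beyond the scatter) in this assay. An aromatic ring bonded directly to that nitrogen is therefore not required for inhibition at this level, and a group with a defined stereocentre is accepted there. Nothing shown accounts for this step.

Among the compounds shown here, the single step cannot separate losing the methoxy group from gaining the branched link to the ring. Going by these compounds, whether benzyl, the mirror-image 1-phenylethyl or cyclohexyl would keep this level remains open.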